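Inverting one ring stereocentre in a thromboxane receptor antagonist

The compounds below may be only part of what the source reports. "The series", "measured", "known", "first", "only" and "open" are said of these compounds alone.

Measured compounds:
Compound 1 `O=C(O)CC/C=C\CO[C@H]1C(OCc2ccc(-c3ccc(CO)cc3)cc2)CC[C@@H]1N1CCCCCC1` — 3.16 nM
Compound 2 `O=C(O)CC/C=C\CO[C@H]1[C@@H](OCc2ccc(-c3ccccc3CO)cc2)CC[C@@H]1N1CCCCCC1` — 1.59 nM
Compound 3 `CS(=O)(=O)Nc1cccc(-c2ccc(COC3CC[C@H](N4CCCCCC4)[C@H]3OC/C=C\CCC(=O)O)cc2)c1` — 12.6 nM

In a functional assay on blood for antagonist activity at thromboxane A2 receptor (Homo sapiens) (a higher number here means weaker binding, a lower number tighter binding), compound 2 gives the lowest of the three numbers. Compound 1 sits nearest to it, and the gap between them is within the scatter, so no order between compound 1 and compound 2 can be read from these values. Compound 3 lies furthest away, beyond the scatter. For the measured compounds named here, the only single-place step among the measured compounds is a 4.0-fold higher number from compound 1 to compound 3 (0.60 log units; beyond the scatter), which exchanges the group on an aromatic carbon.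

Compound 4 `O=C(O)CC/C=C\CO[C@H]1[C@H](OCc2ccc(-c3ccccc3CO)cc2)CC[C@@H]1N1CCCCCC1` is not yet measured. It differs from compound 2 in this way: the two compounds have the same atoms and bonds and differ only in configuration as drawn: 1 of 4 stereo elements differ; a stereocentre at a saturated ring carbon is drawn S in compound 2 and R in compound 4. Both compounds are otherwise identical, so the question is how much the configuration at that saturated ring carbon alone matters.

Going by the values given here, no measured step bears on this change: the one step that is known, from compound 1 to compound 3, alters a substituent rather than a configuration. Inverting a ring stereocentre next to nothing in the data gives a comparison, so the expected size and direction rest on the general observation that mirror arrangements at a ring carbon often weaken binding. The estimated step is a 6.3-fold higher number from compound 2 to compound 4 (0.80 log units; beyond the scatter), with wide uncertainty. For compound 4 the expected value in this assay is 10 nM, with a range from 2 nM to 60 nM.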

Compound 4, dissociation constant: 6.31 nM
Compound 4: the middle estimate sits 1.6-fold (0.20 log units) above what was measured; low and high end bracket the measured number.
By their numbers in this assay, from the lowest: compounds 2, 1, 4 and 3 (each within the scatter of the next, the first and the last beyond it).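

For the compounds shown here, compounds 2 and 4 form the first pair here that tests configuration by itself, and in this assay the inversion gives a 4.0-fold higher number from compound 2 to compound 4 (0.60 log units; beyond the scatter). Going by these compounds alone, until now the only step available concerned a swapped group on an aromatic carbon, so the data could say nothing about the saturated ring carbon; they now show that the way its substituent is arranged in space counts, with the S form as drawn giving the lower number and the R form the higher, even though no atom enters or leaves. The step can be assigned to this one stereocentre and to nothing else because the comparison is clean: the fact that compounds 2 and 4 differ only in the configuration as drawn

The compounds shown leave open whether the inversion would have the same effect with other groups on the biphenyl end, such as an amine or a carboxylic acid in place of the hydroxymethyl group, or with a longer chain carrying that hydroxyl. They also leave open how much the other three stereo elements matter, and whether the gap seen in this assay would hold in any other test of these compounds.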